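This account rests on a few compounds, and the source may have more. Where it says the series, first, only, none or still open, it means among the compounds named here.

Compound 1 `CN1CCN(CCCCOc2c(OCc3ccc(C#N)cc3)cc(O)c3c(=O)cc(-c4ccccc4)oc23)CC1` gives 2420 nM in a functional assay on MCF7 cells (Homo sapiens) for cytotoxicity, read by MTT assay, with a stated time of 72 h; a lower number here means a stronger inhibitor, a higher number a weaker inhibitor. Compound 2 `CN1CCN(CCCCOc2c(OCc3ccco3)cc(O)c3c(=O)cc(-c4ccccc4)oc23)CC1` gives 2770 nM. Compound 3 `CN1CCN(CCCCOc2c(OCc3cccs3)cc(O)c3c(=O)cc(-c4ccccc4)oc23)CC1` gives 3180 nM.

Compound 3 stands at the high end of these three numbers, yet its steps to the others, a 1.1-fold higher number from compound 2 to compound 3 (0.06 log units; within the scatter) and a 1.3-fold higher number from compound 1 to compound 3 (0.12 log units; within the scatter), are within the scatter, so the three cannot be told apart. Compound 4 `CN1CCN(CCCCOc2c(OCc3nc4ccccc4o3)cc(O)c3c(=O)cc(-c4ccccc4)oc23)CC1` differs from compound 3 by 1,3-benzoxazol-2-yl in place of thiophen-2-yl on a saturated chain carbon bound to an oxygen on an aromatic ring. The measured steps bear on this only loosely: each swapped one ring for another at the same place, and all of them, a 1.1-fold higher number from compound 1 to compound 2 (0.06 log units; within the scatter) as well as the two above, stayed within the scatter. A step of similar size, a 1.1-fold higher number from compound 3 to compound 4 (0.04 log units; within the scatter), is therefore expected, with no direction beyond the scatter. Compound 4 is estimated at 3500 nM, between 1500 nM and 8000 nM.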

Compound 4, half-maximal inhibitory concentration: 4980 nM
Beside the measured number, compound 4's estimate is 1.4-fold (0.15 log units) below it, and the stated range covers the measured number.
By their numbers in this assay, from the lowest: compounds 1, 2, 3 and 4 (each within the scatter of the next, the first and the last beyond it).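

In this assay, for the compounds shown here, 1,3-benzoxazol-2-yl gives the first step at this place that passes the scatter, though only modestly (a 2.1-fold higher number from compound 1 to compound 4 (0.31 log units; beyond the scatter)). Against the two smaller rings it cannot be told apart, since both steps stay within the scatter (a 1.6-fold higher number from compound 3 to compound 4 (0.19 log units; within the scatter); a 1.8-fold higher number from compound 2 to compound 4 (0.25 log units; within the scatter)). No measured evidence here explains the difference from 4-cyanophenyl.

Still open, going by these compounds, is whether an amine or a carboxylic acid on this saturated chain carbon would change the number more clearly than swapping one aromatic ring for another.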